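The source may report more compounds than this note shows. Statements on the series, on what has been measured and on what is new or still open speak of the compounds shown alone.

Cytotoxicity is followed in an ADME assay on Vero cells (Chlorocebus sabaeus) for cytotoxicity, read by MTT assay, with a stated time of 72 h; on this read-out higher numbers stand for an effect only at larger amounts of compound and lower numbers for an effect already at smaller amounts. Compound 1 `O=C(Nc1nc(-c2ccccn2)cs1)c1ccc(OCc2ccccc2)cc1` gives 2300 nM, compound 2 `CC(=O)c1cccc(C(=O)Nc2nc(-c3ccccn3)cs2)c1` gives 1500 nM and compound 3 `CC(=O)c1ccc(C(=O)Nc2nc(-c3ccccn3)cs2)cc1` gives 10500 nM. Among the compounds with values here, compound 2 thus has the smallest number so far, although its gap to compound 1 lies within the scatter; only its gap to compound 3 lies beyond it. The next compound is compound 4 `O=C(Nc1nc(-c2ccccn2)cs1)c1cccc(F)c1`, which differs from compound 2 by fluoro in place of acetyl on an aromatic carbon. Within the data shown here, the one measured step that touches the acetyl group is a 4.6-fold higher number from compound 1 to compound 3 (0.66 log units; beyond the scatter), but there it enters rather than leaves and stands para; nothing measured concerns a fluoro group. Any expectation is therefore loose, and a step within the scatter or a modest rise is expected, a 1.7-fold higher number from compound 2 to compound 4 (0.22 log units; within the scatter). Compound 4 is estimated at 2500 nM, range 800 nM to 8000 nM.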

Compound 4, half-maximal effective concentration: 1200 nM
Beside the measured number, compound 4's estimate is 2.1-fold (0.32 log units) above it; the range from low to high includes it.
By their numbers in this assay, from the lowest: compounds 4, 2 and 1 (each within the scatter of the next); then compound 3.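

At this place, meta to a large group, acetyl with its 3 heavy atoms and 1 hydrogen-bond acceptor gives way to fluoro with 1 heavy atom and no hydrogen-bond acceptor, and this assay shows a 1.3-fold lower number from compound 2 to compound 4 (0.10 log units; within the scatter). The acetyl group is therefore not required at this place for a number of this size, and a much smaller group serves as well. No available evidence accounts for this. Open, as far as these compounds go, is whether an amine or a carboxylic acid at this place would leave the number as little moved, and whether the same exchange gives a similar step on another core.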